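Moving the Chlorine on the Benzyl Ring

The source may report more compounds than this note shows. Statements on the series, on what has been measured and on what is new or still open speak of the compounds shown alone.

Compound 1 `COc1ccc(C2N=C(SCc3ccccc3Cl)NC(C)=C2C(=O)Nc2ccc(Br)cc2)cc1` and compound 2 `COc1ccc(C2N=C(SCc3cccc(Cl)c3)NC(C)=C2C(=O)Nc2ccc(Br)cc2)cc1` share one core and differ in a single place: 3-chlorophenyl in place of 2-chlorophenyl on a saturated chain carbon bound to a sulfur In a functional assay on the whole organism (artery, strain albino) with Rattus norvegicus as the target, with a stated time of 720 min, at a dose of 10 mg/kg by the oral route (a lower number here means less inhibition, a higher number more inhibition at the dose given (going by the name of the read-out)), compound 1 gives 10.8%, while compound 2 gives 26.8%, so that the step of a number 16 percentage points higher from compound 1 to compound 2 (beyond the scatter). Compound 3 `CC1=C(C(=O)Nc2ccc([N+](=O)[O-])cc2)C(c2cccc([N+](=O)[O-])c2)N=C(SCc2ccccc2Cl)N1` is built on another core; how its core differs from that of compound 1 is not broken down here. In this assay compound 3 gives 11.3%. Compound 4 `CC1=C(C(=O)Nc2ccc([N+](=O)[O-])cc2)C(c2cccc([N+](=O)[O-])c2)N=C(SCc2cccc(Cl)c2)N1` has not yet been measured and differs from compound 3 by the same change, at the same place: 3-chlorophenyl in place of 2-chlorophenyl on a saturated chain carbon bound to a sulfur Because the step of a number 16 percentage points higher from compound 1 to compound 2 (beyond the scatter) was modest but beyond the scatter, a step of similar size is expected here, a number 14.7 percentage points higher from compound 3 to compound 4 (beyond the scatter). Compound 4 is therefore estimated to give 26% in this assay, with a range from 12% to 40%.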

Compound 4, a percentage reported as inhibition, in the whole organism at one dose (the size of the read-out at that dose, not a potency): 12.9%
Beside the measured number, compound 4's estimate is 13.1 percentage points above it, within the range that was stated.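

In this assay, putting 3-chlorobenzyl in place of 2-chlorobenzyl on the core of compound 3 gives a number 1.6 percentage points higher from compound 3 to compound 4 (within the scatter). For the compounds shown here, the gain seen on the core of compound 1 therefore did not carry over to this second core in the same size: the same change on two cores in this assay, a number 16 percentage points higher (beyond the scatter) from compound 1 to compound 2 and a number 1.6 percentage points higher (within the scatter) from compound 3 to compound 4, 14.4 percentage points apart, beyond the scatter of two such steps With only two pairs, this shows that the effect of the change depends on the core, but it does not show which difference between the cores is responsible or how the change would behave on any further core.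

The compounds shown leave open what an unsubstituted benzyl group or a longer chain on the sulfur would give. They also leave open whether an amine or a carboxylic acid on the benzyl ring would behave differently from chlorine on either core.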